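This account rests on a few compounds, and the source may have more. Where it says the series, first, only, none or still open, it means among the compounds named here.

Measured so far:
compound 1, `O=C(O)c1ccc(-c2cnc(C(=O)CCc3ccc(-c4ccccc4)cc3)o2)cn1`: 44 nM
compound 2, `O=C(CCc1ccc(-c2ccccc2)cc1)c1ncc(-c2ccncc2)o1`: 2.3 nM

Going by the values given here, compound 2 gives the lowest of the two numbers in an assay for inhibition of Fatty-acid amide hydrolase 1 (Rattus norvegicus); a lower number here means a stronger inhibitor, a higher number a weaker inhibitor; its only neighbour is compound 1, separated from it by a 19-fold lower number from compound 1 to compound 2 (1.28 log units; beyond the scatter), a gap beyond the scatter. Compound 3, `COC(=O)c1ccc(-c2cnc(C(=O)CCc3ccc(-c4ccccc4)cc3)o2)nc1`, is not yet measured. The change to be judged is 5-(methoxycarbonyl)pyridin-2-yl in place of pyridin-4-yl on an aromatic carbon. Among the compounds with values here, the one measured step that bears on it is a 19-fold lower number from compound 1 to compound 2 (1.28 log units; beyond the scatter): a pyridine carrying an acid gives a much higher number than the plain pyridin-4-yl. Compound 3 carries a methoxycarbonyl on a pyridin-2-yl, not a carboxy on a pyridin-3-yl, so the step of compound 1 is only a rough guide and the substituted ring is expected to cost potency, but by less than that step. Compound 3 is therefore expected at 10 nM with a range of 3 nM to 40 nM, an expected step of a 4.3-fold higher number from compound 2 to compound 3 (0.64 log units; beyond the scatter) in this assay.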

Compound 3, inhibition constant: 2.2 nM
Compound 3: middle estimate off by 4.5-fold (0.66 log units), on the high side; measured number below the stated range.
By their numbers in this assay, from the lowest: compounds 3 and 2 (each within the scatter of the next); then compound 1.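

In this assay, the place next to the ring oxygen takes 5-(methoxycarbonyl)pyridin-2-yl as readily as pyridin-4-yl, with a 1.0-fold lower number from compound 2 to compound 3 (0.02 log units; within the scatter), so the larger group with its added methoxycarbonyl carries no measurable cost here. Not every substituted pyridine here gives a weak number. The step between the two substituted pyridines is a 20-fold lower number from compound 1 to compound 3 (1.30 log units; beyond the scatter), and 6-carboxypyridin-3-yl alone stands apart among the three groups. No measurement at hand accounts for this difference.

Compound 1 and compound 3 differ both in carboxylic acid versus methyl ester and in how the pyridine is attached, so the two changes remain unseparated; a carboxylic acid on the pyridin-2-yl ring would divide them. From the compounds shown here alone, whether an amide or an amine in the ester's place behaves like the methoxycarbonyl also remains open.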